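Adding Cyclopropylmethyl to Compound 3

This account rests on a few compounds, and the source may have more. Where it says the series, first, only, none or still open, it means among the compounds named here.

Measured in a physicochemical assay for solubility, read by HPLC, using the shake flask method, in phosphate buffer, with a stated time of 20 h, at pH 6.5; a higher number here means a more soluble compound, a lower number a less soluble compound:
compound 1 `Fc1ccc(-c2nc3c(C4CCNCC4)nccc3[nH]2)cc1F` gives 200000 nM
compound 2 `C[C@@H]1CN(c2nccc3[nH]c(-c4ccc(F)c(F)c4)nc23)C[C@H](C)N1` gives 190000 nM
compound 3 `Fc1ccc(-c2nc3c(N4CCCNCC4)nccc3[nH]2)cc1F` gives 165000 nM

Compound 3 stands level with the other two, as the steps show: a 1.2-fold lower number from compound 1 to compound 3 (0.08 log units; within the scatter) and a 1.2-fold lower number from compound 2 to compound 3 (0.06 log units; within the scatter). The remaining step, a 1.1-fold lower number from compound 1 to compound 2 (0.02 log units; within the scatter), is no larger. Compound 4 `Fc1ccc(-c2nc3c(N4CCCN(CC5CC5)CC4)nccc3[nH]2)cc1F` carries cyclopropylmethyl in place of hydrogen on an amine nitrogen in a ring. These measured steps only exchange one ring for another, and none adds a group to such a nitrogen, so they bear on this change only loosely. A modest move in this assay is expected, with wide uncertainty: a 1.5-fold lower number from compound 3 to compound 4 (0.18 log units; within the scatter). Compound 4 is estimated at 110000 nM, within an expected range of 40000 nM to 200000 nM.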

Compound 4, solubility: 200000 nM
For compound 4 the middle estimate is 1.8-fold (0.26 log units) below the measured one; measured number inside the range.
By their numbers in this assay, from the lowest: compounds 3, 2, 1 and 4 (each within the scatter of the next).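

In this assay, the new step reads a 1.2-fold higher number from compound 3 to compound 4 (0.08 log units; within the scatter), so compound 3 and compound 4 stand level. The earlier compounds shown here only exchanged one ring for another, whereas this pair shows cyclopropylmethyl in place of hydrogen on the amine nitrogen of the seven-membered ring. Nothing measured here accounts for this result. As far as these compounds go, whether an acetyl group or a longer alkyl chain on this nitrogen would also leave the number level stays open, as does whether cyclopropylmethyl would do so on the ring nitrogen of compound 1 or compound 2.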